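Shifting a fluorine: from compound 2 to compound 3

The source may hold more compounds than are shown below. What is called first, only, known or untested is meant among the compounds shown, and "the series" means these compounds.

Compound 1 `CCCNc1cccc(NC(=O)c2ccc(OCCC)cc2)n1`: 15400 nM
Compound 2 `CCCOc1ccc(C(=O)Nc2cccc(Nc3ccccc3F)n2)cc1`: > 100000 nM

Of the compounds shown here, two have been measured in an in vitro assay on HEK-tsA201 cells for antagonist activity at Neuronal acetylcholine receptor; alpha4/beta2 (Homo sapiens), read by fluorescence and calcium flux; on this read-out lower numbers stand for stronger inhibition and higher numbers for weaker inhibition. Compound 1 gives 15400 nM. Compound 2 reaches only the limit of the assay, > 100000 nM, so no number is known for it. For the measured compounds named here, the one measured step is an at least 6.4-fold higher number from compound 1 to compound 2 (0.81 log units; beyond the scatter), and the limit of > 100000 nM in this assay, at which 1 of the 2 values shown sits, leaves its true size open. Compound 3 `CCCOc1ccc(C(=O)Nc2cccc(Nc3ccc(F)cc3)n2)cc1` differs from compound 2 by 4-fluorophenyl in place of 2-fluorophenyl on a nitrogen on an aromatic ring. Going by the values given here, no measured step touches this change, so a number no higher from compound 2 to compound 3 (the limit leaves the size open) is expected to be no larger than the usual scatter. The estimate for compound 3 is 100000 nM, between 30000 nM and 300000 nM, most likely again a limit.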

Compound 3, half-maximal inhibitory concentration: > 100000 nM
Compound 3 was reported as a limit (the forecaster's own chance of this, stated with the estimate: 60%); the middle value lies on the limit itself.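

Moving the fluorine to give 4-fluorophenyl brings no measurable inhibition back: in this assay, compound 3 again sits at a limit of the assay, > 100000 nM. Both fluorophenyl groups on this nitrogen therefore fall short of propyl, and 4-fluorophenyl in place of propyl gives an at least 6.4-fold higher number from compound 1 to compound 3 (0.81 log units; beyond the scatter). The step between the two fluorophenyl compounds cannot be read: the limit of > 100000 nM in this assay, at which 2 of the 3 values shown sit.

Going by these compounds, how far either compound lies past the limit stays open, so the two fluorine placements cannot be ranked. Also open, on these data alone, is how a butyl chain or an unsubstituted phenyl on this nitrogen would compare with propyl.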